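Swapping a Hydroxy for an Ethynyl on a Shared Core

This account rests on a few compounds, and the source may have more. Where it says the series, first, only, none or still open, it means among the compounds named here.

Measured compounds:
- compound 1, `CC1CN(CCn2ccc3ccc(Br)cc32)CC(C)N1`: 26%
- compound 2, `CN1CCCN(CCn2ccc3ccc(O)cc32)CC1`: 28%

Both values come from an assay on HEK293 cells for binding affinity to 5-hydroxytryptamine receptor 7 (Homo sapiens), read by radioligand binding, tested at 1 uM; a lower number here means less inhibition, a higher number more inhibition at the concentration tested (going by the name of the read-out). Compound 2 stands at the higher of the two numbers, yet its nearest neighbour, compound 1, sits only slightly lower, a gap within the usual scatter of such measurements. The two numbers therefore look alike in this assay, and compound 2 cannot be said to give a higher inhibition than compound 1 on this evidence. Within the data shown here, no step between compounds that differ in a single place is available here, so there is no measured guide for how a change on the aromatic ring shifts the read-out.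

Compound 3, `C#Cc1ccc2ccn(CCN3CCCN(C)CC3)c2c1`, differs from compound 2 in one place: ethynyl in place of hydroxy on an aromatic carbon. Given that compound 2 gives 28% and that nothing shown points to a larger or smaller number, compound 3 is expected to behave much like compound 2, with a step of a number 2 percentage points higher from compound 2 to compound 3 (within the scatter) that stays within the scatter. Compound 3 is thus estimated to give 30% in this assay, likely between 12% and 50%.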

Compound 3, a percentage reported as inhibition, at one concentration (the size of the read-out at that concentration, not a potency): 79%
The estimate for compound 3 lay 49 percentage points below the measured number; the whole stated range lies below it.
By their numbers in this assay, from the lowest: compounds 1 and 2 (each within the scatter of the next); then compound 3.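

In this assay, among these compounds, ethynyl in place of hydroxy on this aromatic carbon gives a step of a number 51 percentage points higher from compound 2 to compound 3 (beyond the scatter) and so marks this one place on the six-membered aromatic ring as able to move the read-out strongly, which the earlier compounds could not show, as they offered no comparison of a single change. The swap replaces a group with 1 hydrogen-bond donor and 1 hydrogen-bond acceptor by one with 0 of each, and it also brings in a triple bond and a second heavy atom, but one step cannot separate these differences from one another. Nothing measured here accounts for the size of the step.

On these data alone, whether the high number is particular to ethynyl remains open, as a nitrile, a methyl group, an amine or a longer alkyne such as propynyl at the same place could land anywhere relative to compound 3. Also open, as far as these compounds go, is whether ethynyl would give a similar step on a core carrying the different side chain of compound 1.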